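Ester to carboxy exchange on the anilino nitrogen

The compounds below may be only part of what the source reports. "The series", "measured", "known", "first", "only" and "open" are said of these compounds alone.

Measured in a functional assay on DU-145 cells (Homo sapiens) for cytotoxicity, read by trypan blue exclusion, with a stated time of 96 h; on this read-out lower numbers stand for stronger inhibition and higher numbers for weaker inhibition:
- compound 1 `COc1cc(OC)c(/C=C/S(=O)(=O)Nc2ccc(OC)c(OP(=O)(O)O)c2)c(OC)c1`: 40 nM
- compound 2 `COc1cc(OC)c(/C=C/S(=O)(=O)Nc2ccc(OC)c([N+](=O)[O-])c2)c(OC)c1`: 2500 nM
- compound 3 `COC(=O)C(Nc1cc(NS(=O)(=O)/C=C/c2c(OC)cc(OC)cc2OC)ccc1OC)c1ccc(F)cc1`: 2500 nM

Compound 3 stands level with compound 2, together the highest numbers in the set, well beyond the scatter from compound 1.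

Compound 4 `COc1cc(OC)c(/C=C/S(=O)(=O)Nc2ccc(OC)c(NC(C(=O)O)c3ccc(Cl)cc3)c2)c(OC)c1` is next: carboxy(4-chlorophenyl)methyl in place of (4-fluorophenyl)(methoxycarbonyl)methyl on a nitrogen on an aromatic ring. Going by the values given here, no measured step covers this exchange directly. The nearest evidence is a 63-fold higher number from compound 1 to compound 2 (1.80 log units; beyond the scatter), which shows that a change of group on the shared core can move the number widely. Compound 3 already sits at the high end, so the likely movement is downward, but the size is uncertain.

A lower number is expected in this assay, an estimated 8.3-fold lower number from compound 3 to compound 4 (0.92 log units; beyond the scatter). For compound 4 the expected value is 300 nM, with an estimated range of 40 nM to 2500 nM.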

Compound 4, half-maximal inhibitory concentration: 75 nM
Compound 4: the middle estimate sits 4.0-fold (0.60 log units) above what was measured, and the stated range covers the measured number.
By their numbers in this assay, from the lowest: compounds 1 and 4 (each within the scatter of the next); then compounds 2 and 3 (each within the scatter of the next).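

The exchange on the nitrogen gives a 33-fold lower number from compound 3 to compound 4 (1.52 log units; beyond the scatter) in this assay and shows that a change on this nitrogen alone can move the number widely. Against the nitro group, (carboxy(4-chlorophenyl)methyl)amino gives a 33-fold lower number from compound 2 to compound 4 (1.52 log units; beyond the scatter) and against the phosphorus-bearing group it gives a 1.9-fold higher number from compound 1 to compound 4 (0.27 log units; within the scatter) so, among these compounds, phosphorus is not required for a number of this size. No measurement at hand accounts for these steps.

The carboxy group and chlorine enter together, so the separate contribution of each stays unresolved. A methyl ester with 4-chlorophenyl, a carboxylic acid with 4-fluorophenyl, or a primary amide would address this.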